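The compounds below may be only part of what the source reports. "The series", "measured", "known", "first", "only" and "open" are said of these compounds alone.

In an ADME assay on L929 cells (Mus musculus) for cytotoxicity, read by resazurin assay, with a stated time of 72 h (a higher number here means a weaker inhibitor, a lower number a stronger inhibitor), compound 1 `Nc1ccc(C(=O)/C=C/c2ccc3c(c2)B(O)OC3)cc1` gives > 10 ug/mL, which is a limit of the assay and not a number. Compound 2 `O=C(/C=C/c1ccc2c(c1)B(O)OC2)c1ccc(I)cc1` gives > 10 ug/mL, again a limit. Compound 3 `Cc1ccc(C(=O)/C=C/c2ccc3c(c2)B(O)OC3)cc1` gives > 10 ug/mL, also a limit, so it has no exact value. Compound 4 `COc1ccc(C(=O)/C=C/c2ccc3c(c2)B(O)OC3)cc1` carries methoxy in place of methyl on an aromatic carbon, para to a large group, relative to compound 3: methoxy in place of methyl on an aromatic carbon. Two measured steps end in that same methyl: a step that the two limits leave unreadable from compound 1 to compound 3 and a step that the two limits leave unreadable from compound 2 to compound 3. Neither gives a size, and the three compounds share (the limit of > 10 ug/mL in this assay, at which 3 of the 3 values shown sit). No step beyond the scatter is therefore expected in this assay, in either direction. The estimated change is a step that the limit leaves unreadable from compound 3 to compound 4. Compound 4 is estimated at 20 ug/mL, with an expected range from 10 ug/mL to 50 ug/mL.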

Compound 4, half-maximal inhibitory concentration: > 10 ug/mL
Compound 4 ended at the assay's limit; the forecaster's own chance of this, stated with the estimate: 85%; the middle value lies beyond the limit too.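

Compound 4 adds no readable step, and the steps among compound 1, compound 2, compound 3 and compound 4 all stay unreadable, because every value is a limit: the limit of > 10 ug/mL in this assay, at which 4 of the 4 values shown sit.
The compounds shown leave open whether amino, iodo, methyl and methoxy differ at all in this assay once exact values exist.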